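One Chloro Becomes Methoxy: Expected Change in Inhibition

The source may report more compounds than this note shows. Statements on the series, on what has been measured and on what is new or still open speak of the compounds shown alone.

The set comprises four compounds on a shared core, examined in an assay on HEK293 cells for inhibition of cyclin-dependent kinase 14 (Homo sapiens), with a stated time of 4 h; on this read-out lower numbers stand for stronger inhibition and higher numbers for weaker inhibition. Compound 1 `CCC(=O)Nc1cccc(CN2CCC(NC(=O)c3n[nH]cc3NC(=O)c3c(Cl)cccc3Cl)CC2)c1` gives > 1000 nM, which is a limit of the assay and not a number, namely (the limit of > 1000 nM in this assay, at which 1 of the 3 values shown sits). Compound 2 `CN(C)C/C=C/C(=O)Nc1cccc(C(=O)Nc2ccc(NC(=O)c3n[nH]cc3NC(=O)c3c(Cl)cccc3Cl)cc2)c1` gives 1000 nM in this assay. Compound 3 `COc1cccc(Cl)c1C(=O)Nc1c[nH]nc1C(=O)NC1CCN(S(=O)(=O)c2cccc(NC(=O)/C=C/CN(C)C)c2)CC1` gives 50 nM; in it a methoxy stands where compounds 1 and 2 carry a second chloro. This is the lower of the two numbers recorded, and its gap to compound 2 lies beyond the usual scatter of repeated measurements.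

Compound 4 `COc1cccc(OC)c1C(=O)Nc1c[nH]nc1C(=O)NC1CCN(S(=O)(=O)c2cccc(NC(=O)/C=C/CN(C)C)c2)CC1` has not yet been measured. It differs from compound 3 in a single place: methoxy in place of chloro on an aromatic carbon. The change sits on an aromatic carbon ortho to a large group and meta to a methoxy group, so the ring ends up carrying two methoxy groups. For the measured compounds named here, no measured pair in this set shows the same exchange, so its effect can only be estimated from compound 3. A small weakening is expected for compound 4, a step of a 2.2-fold higher number from compound 3 to compound 4 (0.34 log units; beyond the scatter) from compound 3, though a result within the scatter would not be surprising. Compound 4 is therefore estimated to give about 110 nM in this assay, with a likely range from 35 nM to 400 nM.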

Compound 4, half-maximal inhibitory concentration: > 1000 nM
Compound 4 gave a limit, no number; the forecaster's own chance of this, stated with the estimate: 5%; middle value at least 9.0-fold (0.95 log units) from the limit.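

Exchanging the chloro for a methoxy on the aromatic carbon ortho to a large group, which turns the 2-chloro-6-methoxyphenyl into a 2,6-dimethoxyphenyl, gives an at least 20-fold higher number from compound 3 to compound 4 (1.30 log units; beyond the scatter) in this assay. For the compounds shown here, this is the first direct reading of this position, since no two of the earlier compounds differed in one place, and it shows that inhibition on this read-out depends strongly on which group sits there: the single exchange of one heavy atom for two takes the compound from a measured number to the top of the measured range. For compound 4, > 1000 nM is a limit of the assay and not a number, so the step gives only the smallest possible size of the change, and the true size remains unknown: the limit of > 1000 nM in this assay, at which 2 of the 4 values shown sit.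

The compounds shown leave open whether the weakening belongs to methoxy itself or would also follow from another group at this position, such as fluoro, methyl or hydroxy. They also leave open whether the same exchange would have a comparable effect on a ring that does not already carry a methoxy.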